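Triazole in Place of Imidazole: An Expected Step

The compounds below may be only part of what the source reports. "The series", "measured", "known", "first", "only" and "open" are said of these compounds alone.

Compound 1 `COC(=O)C(C)(C)C(c1ccc(Nc2ccccc2)cc1)n1cncn1` gives 13 nM in an assay on microsomes from MCF7 cells for inhibition of cytochrome P450 26A1 (Homo sapiens), read by scintillation counting, with a stated time of 1 h; on this read-out higher numbers stand for weaker inhibition and lower numbers for stronger inhibition.
Compound 2 `CNC(=O)C(C)(C)C(c1ccc(Nc2ccccc2)cc1)n1ccnc1` gives 200 nM in this assay.

Of the two numbers, compound 2 holds the higher one. Its nearest neighbour is compound 1, whose value lies far below, a gap beyond the usual scatter. The two compounds differ in more than one place, so their values show only the combined gap and no single step can be read from them.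

Compound 3 `CNC(=O)C(C)(C)C(c1ccc(Nc2ccccc2)cc1)n1cncn1` keeps the amide of compound 2 and changes only the ring on the chain: 1H-1,2,4-triazol-1-yl in place of 1H-imidazol-1-yl on a saturated chain carbon bound to an aromatic carbon and a saturated chain carbon. Within the data shown here, the only measured compound carrying the triazole is compound 1, which gives 13 nM in this assay; the only one carrying the imidazole is compound 2, which gives 200 nM. Because compound 1 with the triazole gives 13 nM, a downward step a 3.3-fold lower number from compound 2 to compound 3 (0.52 log units; beyond the scatter) is expected, though the amide of compound 2 is retained and its own part in the gap is not separable. Compound 3 is therefore estimated at 60 nM, between 15 nM and 250 nM.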

Compound 3, half-maximal inhibitory concentration: 1000 nM
Estimate against measurement, compound 3: 17-fold (1.22 log units) below; the measured number lies above the stated range.
By their numbers in this assay, from the lowest: compound 1; then compound 2; then compound 3.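

With the amide held fixed, 1H-1,2,4-triazol-1-yl in place of 1H-imidazol-1-yl on the saturated chain carbon gives a 5.0-fold higher number from compound 2 to compound 3 (0.70 log units; beyond the scatter) in this assay, so at this position and with this amide the triazole is the less favourable of the two rings, and the low number of compound 1 cannot be credited to the triazole alone. With the triazole held fixed, methylamino in place of methoxy on the carbonyl carbon gives a 77-fold higher number from compound 1 to compound 3 (1.89 log units; beyond the scatter), which shows that the methyl ester of compound 1 matters strongly and that the combined gap between the first two compounds contains two single changes of opposite direction on the read-out. Nothing given here offers a reason for either step.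

From the compounds shown here alone, whether the ring change would run the same way with methoxy on the carbonyl carbon stays open, as does the size of the methoxy step with 1H-imidazol-1-yl on the chain. Going by these compounds, how other groups on the carbonyl carbon, such as ethoxy, dimethylamino or a hydroxyl giving a free carboxylic acid, would read also remains open.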